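Chloro in Place of Nitro on a Shared Core

The source may report more compounds than this note shows. Statements on the series, on what has been measured and on what is new or still open speak of the compounds shown alone.

Compound 1, with the structure `COc1cc(OC)c2c(=O)cc(/C=C/c3ccc([N+](=O)[O-])cc3)oc2c1`, was tested in a functional assay on PC-3 cells (Homo sapiens) for antiproliferative activity, read by MTT assay, with a stated time of 12 h; a lower number here means a stronger inhibitor, a higher number a weaker inhibitor. In this assay compound 1 reaches only the limit of the assay, > 40000 nM, so no number is known for it. Compound 2, `COc1ccc2oc(/C=C/c3ccc(OC(F)(F)F)cc3)cc(=O)c2c1`, likewise gives only a limit in this assay, > 40000 nM. Compound 3, `COc1cccc2oc(/C=C/c3ccc(OC(F)(F)F)cc3)cc(=O)c12`, also stops at the limit in this assay, > 40000 nM. Among the compounds with values here, compound 1 thus stands where the other two values stand, at the limit of > 40000 nM in this assay, at which 3 of the 3 values shown sit, and no step between measured compounds is available to lean on.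

Compound 4, `COc1cc(OC)c2c(=O)cc(/C=C/c3ccc(Cl)cc3)oc2c1`, has not yet been measured. It differs from compound 1 in one place: chloro in place of nitro on an aromatic carbon. With nothing but limits in hand, the expected step of a number no higher from compound 1 to compound 4 (the limit leaves the size open) is taken to be none beyond the scatter. The most likely outcome for compound 4 in this assay is expected to be another limit. The estimate for compound 4 in this assay is 40000 nM, expected to lie between 10000 nM and 100000 nM.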

Compound 4, half-maximal inhibitory concentration: > 40000 nM
Compound 4 gave a limit, no number; the forecaster's own chance of this, stated with the estimate: 70%; the middle value sits exactly at the limit.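

Compound 1 and compound 4 both stop at a limit rather than a number, so no step can be read for chloro in place of nitro: the limit of > 40000 nM in this assay, at which 4 of the 4 values shown sit.

The compounds shown leave open how strongly any of them acts in this assay, and whether nitro or chloro gives the stronger inhibitor.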